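Amide aryl swap on the shared fluoropyrimidine core

The compounds below may be only part of what the source reports. "The series", "measured", "known", "first", "only" and "open" are said of these compounds alone.

Compound 1 `O=C(c1cccc(Nc2ncc(F)c(Nc3ccc(F)cc3)n2)c1)N1CCCCC1` carries piperidin-1-yl on the carbonyl carbon of the shared core; in a functional assay on DU-145 cells (Homo sapiens) for antiproliferative activity, read by sulforhodamine B assay, with a stated time of 3 days (on this read-out lower numbers stand for stronger inhibition of growth and higher numbers for weaker inhibition of growth), compound 1 gives 13000 nM. Compound 2 `COc1ccc(NC(=O)c2cccc(Nc3ncc(F)c(Nc4ccc(F)cc4)n3)c2)cc1` has (4-methoxyphenyl)amino in its place. In this assay compound 2 gives > 10000 nM, which is a limit of the assay and not a number. Compound 3 `O=C(Nc1cc(Cl)cc(Cl)c1)c1cccc(Nc2ncc(F)c(Nc3ccc(F)cc3)n2)c1` bears (3,5-dichlorophenyl)amino on the carbonyl carbon; in this assay compound 3 gives 17500 nM, the higher of the two numbers, though the step of a 1.3-fold higher number from compound 1 to compound 3 (0.13 log units; within the scatter) stays within the scatter. The step that the limit leaves unreadable from compound 2 to compound 3 cannot be sized because of the limit (the limit of > 10000 nM in this assay, at which 1 of the 3 values shown sits).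

Compound 4 `O=C(Nc1ccc(C(F)(F)F)cc1)c1cccc(Nc2ncc(F)c(Nc3ccc(F)cc3)n2)c1` differs from compound 3 by 4-(trifluoromethyl)phenyl in place of 3,5-dichlorophenyl on an amide-type nitrogen. The evidence bearing on this position is thus one step within the scatter and one unreadable step, so no change beyond the scatter is expected in this assay. Compound 4 is therefore estimated at 16000 nM, with a range from 6000 nM to 40000 nM, meaning an expected step of a 1.1-fold lower number from compound 3 to compound 4 (0.04 log units; within the scatter).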

Compound 4, concentration for 50% growth inhibition: > 10000 nM
Compound 4: no number, only a limit (the forecaster's own chance of this, stated with the estimate: 40%); the middle value is on the limit's open side.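

No step from compound 1, compound 2 or compound 3 to compound 4 can be read, because compound 4 gives a limit of the assay and not a number: the limit of > 10000 nM in this assay, at which 2 of the 4 values shown sit.

The compounds shown leave open where compound 2 and compound 4 actually sit relative to compound 1 and compound 3 in this assay.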